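The compounds below may be only part of what the source reports. "The series", "measured", "known", "first", "only" and "open" are said of these compounds alone.

Working notes on the series. Compound 1 `CO[C@@H]1C(=O)C[C@H]2O[C@]1(C)n1c3ccccc3c3c4c(c5c6ccccc6n2c5c31)C(=O)NC4` is one of two compounds with a result in an assay on isolated protein for inhibition of protein kinase C theta type (Homo sapiens), read by HTRF; on this read-out higher numbers stand for weaker inhibition and lower numbers for stronger inhibition; in this assay compound 1 gives only > 2500 nM, which is a limit of the assay and not a number. Compound 2 `CO[C@@H]1[C@H](NC(C)=O)C[C@H]2O[C@]1(C)n1c3ccccc3c3c4c(c5c6ccccc6n2c5c31)C(=O)NC4` carries an acetamido group on the shared core, and in this assay compound 2 gives 38 nM. For the measured compounds named here, that is the only finite number on hand; the other entry sits at the limit of > 2500 nM in this assay, at which 1 of the 2 values shown sits, and belongs to compound 1. Compound 2 therefore stands as the sole anchor for any expectation in this series.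

Compound 3 `CO[C@@H]1[C@H](NC=O)C[C@H]2O[C@]1(C)n1c3ccccc3c3c4c(c5c6ccccc6n2c5c31)C(=O)NC4` differs from compound 2 by hydrogen in place of methyl on a carbonyl carbon. The acetyl becomes a formyl, the acetamido a formylamino; the amide-type nitrogen and the carbonyl stay in place. Going by the values given here, no measured step of this kind is available, so the change is judged on its size alone. In this assay the expected step is a 1.4-fold higher number from compound 2 to compound 3 (0.16 log units; within the scatter), small and within the usual scatter, with at most a slight loss of potency. For compound 3 in this assay the estimate is 55 nM, with a range from 20 nM to 150 nM.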

Compound 3, half-maximal inhibitory concentration: > 2500 nM
Compound 3 ended at the assay's limit (the forecaster's own chance of this, stated with the estimate: 3%); at least 45-fold (1.65 log units) between middle value and limit.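

The position is far less tolerant than the size of the change suggested: swapping acetyl for formyl, with the amide-type nitrogen and the carbonyl left in place, gives an at least 65-fold higher number from compound 2 to compound 3 (1.81 log units; beyond the scatter) in this assay. So the methyl on this carbonyl carbon matters to the result, and the carbonyl and amide-type nitrogen alone do not keep a finite value in this assay. The step is a bound and its true size cannot be read, as compound 3 rests on a limit of the assay, and compound 2 is left as the only compound shown with a finite number, set against the following: the limit of > 2500 nM in this assay, at which 2 of the 3 values shown sit.

Going by these compounds, whether the methyl can be replaced by anything other than hydrogen stays open, for example by an ethyl group or a longer chain, a cyclopropyl group, or a methoxy group, each as a change from compound 2 at 38 nM. Also open is whether a free amine or a methanesulfonamide in place of the acetamido would hold a finite value, and the compounds shown give no reason for the loss on going to formylamino.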